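Fluoro step on the chloro member of the series

The compounds below may be only part of what the source reports. "The series", "measured", "known", "first", "only" and "open" are said of these compounds alone.

Compound 1 `O=[N+]([O-])c1cc(C(F)(F)F)cc([N+](=O)[O-])c1Oc1ccccc1/C=N\OCc1ccccc1` gives 1330 nM
Compound 2 `O=[N+]([O-])c1cc(C(F)(F)F)cc([N+](=O)[O-])c1Oc1ccccc1/C=N\OCc1ccccc1F` gives 700 nM
Compound 3 `O=[N+]([O-])c1cc(C(F)(F)F)cc([N+](=O)[O-])c1Oc1ccc(Cl)cc1/C=N\OCc1ccccc1` gives 1220 nM

In a functional assay on MCF7 cells (Homo sapiens) for antiproliferative activity, read by MTT assay, with a stated time of 48 h (on this read-out lower numbers stand for stronger inhibition and higher numbers for weaker inhibition), compound 3 at 1220 nM lies within the scatter of both compound 1 and compound 2, so the three values do not separate. The next step leads to compound 4 `O=[N+]([O-])c1cc(C(F)(F)F)cc([N+](=O)[O-])c1Oc1ccc(Cl)cc1/C=N\OCc1ccccc1F` and is fluoro in place of hydrogen on an aromatic carbon in all: fluoro in place of hydrogen on an aromatic carbon, ortho to a large group, which turns benzyl into 2-fluorobenzyl. The same change occurs once among the measured pairs, as a 1.9-fold lower number from compound 1 to compound 2 (0.28 log units; within the scatter) and within the scatter. The chloro step a 1.1-fold lower number from compound 1 to compound 3 (0.04 log units; within the scatter) also lies within the scatter. Whether the fluoro change carries over with chloro present has not been tested. Resting on a 1.9-fold lower number from compound 1 to compound 2 (0.28 log units; within the scatter) as the only precedent, a step of similar size toward a lower number is expected in this assay and it may not exceed the scatter. The expected change is a 1.7-fold lower number from compound 3 to compound 4 (0.24 log units; within the scatter) as a working figure. In this assay compound 4 is estimated at 700 nM within an expected range of 340 nM to 1350 nM for a single measurement.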

Compound 4, half-maximal inhibitory concentration: 1110 nM
Beside the measured number, compound 4's estimate is 1.6-fold (0.20 log units) below it, and the stated range covers the measured number.
By their numbers in this assay, from the lowest: compounds 2, 4, 3 and 1 (each within the scatter of the next).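

In this assay, benzyl to 2-fluorobenzyl on the chloro member gives a 1.1-fold lower number from compound 3 to compound 4 (0.04 log units; within the scatter), and chloro in place of hydrogen with 2-fluorobenzyl already present gives a 1.6-fold higher number from compound 2 to compound 4 (0.20 log units; within the scatter). The fluoro change can now be read on two cores, and neither reading leaves the scatter, so these compounds show no measurable response to fluoro at this position: the same change on two cores in this assay, a 1.9-fold lower number (0.28 log units; within the scatter) from compound 1 to compound 2 and a 1.1-fold lower number (0.04 log units; within the scatter) from compound 3 to compound 4, 1.7-fold (0.24 log units) apart, within the scatter of two such steps The chloro change also has two readings, and they do not separate either: the same change on two cores in this assay, a 1.1-fold lower number (0.04 log units; within the scatter) from compound 1 to compound 3 and a 1.6-fold higher number (0.20 log units; within the scatter) from compound 2 to compound 4, 1.7-fold (0.24 log units) apart, within the scatter of two such steps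

Open, going by these compounds, is whether an amine or a carboxylic acid in place of the fluoro, or a longer chain in place of benzyl, would give a step beyond the scatter. With all steps inside the scatter, these four compounds cannot show whether fluoro and chloro act independently.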